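The source may report more compounds than this note shows. Statements on the series, on what has been measured and on what is new or still open speak of the compounds shown alone.

In a functional assay on HL-60 cells (Homo sapiens) for inhibition, read by CCK-8 assay, with a stated time of 48 h (a higher number here means a weaker inhibitor, a lower number a stronger inhibitor), compound 1 (`O=C(Nc1cccc([N+](=O)[O-])c1)N1CCN(S(=O)(=O)c2sccc2-c2ccccc2Oc2ccc(O)c(O)c2)CC1`) gives 4500 nM and compound 3 (`Cc1ccc(-c2ccsc2S(=O)(=O)NCCNC(=O)Nc2ccc([N+](=O)[O-])cc2)c(Oc2ccc(O)c(O)c2)c1`) gives 3900 nM as a value within the scatter of the first. Compound 2 (`COc1ccc(Oc2ccccc2-c2ccsc2S(=O)(=O)N2CCN(C(=O)Nc3cccc([N+](=O)[O-])c3)CC2)cc1OC`) gives > 50000 nM as a limit of the assay and not a number. Compound 1 thus stands together with compound 3, and no order can be read between the two.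

The change to compound 4 (`O=C(Nc1ccc([N+](=O)[O-])cc1)N1CCN(S(=O)(=O)c2sccc2-c2ccccc2Oc2ccc(O)c(O)c2)CC1`) is 4-nitrophenyl in place of 3-nitrophenyl on an amide-type nitrogen with the same atoms joined differently. Within the data shown here, the one measured step is an at least 11-fold higher number from compound 1 to compound 2 (1.04 log units; beyond the scatter) with 3,4-dimethoxyphenyl in place of 3,4-dihydroxyphenyl on an oxygen on an aromatic ring. Its size is bounded by the limit of > 50000 nM in this assay, at which 1 of the 3 values shown sits, and is not an exact figure. Among the measured compounds shown here, that step lies elsewhere in the structure, and no measured step touches the nitrophenyl group, so it offers no size for this change.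

Compound 4 keeps the 3,4-dihydroxyphenyl group of compound 1 at 4500 nM and so no step beyond the scatter is expected. The expected step is a 1.1-fold lower number from compound 1 to compound 4 (0.05 log units; within the scatter) with a wide margin on either side. In this assay the estimate for compound 4 is 4000 nM within an expected range of 1500 nM to 12000 nM for now.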

Compound 4, half-maximal inhibitory concentration: 4900 nM
Beside the measured number, compound 4's estimate is 1.2-fold (0.09 log units) below it; the measured number falls inside the stated range.
By their numbers in this assay, from the lowest: compounds 3, 1 and 4 (each within the scatter of the next). At a limit, above all of these: compound 2.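

In this assay, among these compounds, 4-nitrophenyl in place of 3-nitrophenyl on the amide-type nitrogen gives a 1.1-fold higher number from compound 1 to compound 4 (0.04 log units; within the scatter) and is the first measured step at the nitrophenyl group. Within this pair, the change of name from 3-nitrophenyl to 4-nitrophenyl does not separate the two compounds, so the only clear response in the shown set remains the one at the 3,4-dihydroxyphenyl group, where compound 2 gives > 50000 nM as a limit of the assay. No measurement shown bears on why compound 1 and compound 4 stand together.

Open, on these data alone, is whether this place on the amide-type nitrogen responds to anything other than a nitrophenyl group, since the pair varies only how the same atoms are joined and so says nothing about the nitro group itself. An aminophenyl or carboxyphenyl group, or a longer chain in place of the whole ring, would show whether the value of compound 4 (4900 nM) holds once the atoms there change.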